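Phenyl for ethoxy on a cytotoxicity limit

A few compounds are considered here, and "the series" means these few. Any claim that something is new, unique, unknown or untested is made for them only; others in the source may bear on it.

- compound 1 `C=C[C@@](C)(/C=C/c1ccc(O)cc1)CCC1OC1(C)C` gives > 36600 nM
- compound 2 `C=C[C@@](C)(/C=C/c1ccc(O)cc1)CC/C=C/C(=O)OCC` gives > 36600 nM
- compound 3 `C=C[C@@](C)(/C=C/c1ccc(O)cc1)CC/C=C/C(=O)c1ccccc1` is not yet measured

Compound 2 gives > 36600 nM in an ADME assay on HEK293 cells (Homo sapiens) for cytotoxicity, with a stated time of 72 h (on this read-out lower numbers stand for an effect already at smaller amounts and higher numbers for an effect only at larger amounts of compound), as a limit and not a number. Compound 1 gives > 36600 nM as a limit too. Compound 3 differs from compound 2 by phenyl in place of ethoxy on a carbonyl carbon with phenyl in place of ethoxy on a carbonyl carbon. For the measured compounds named here, the only measured step is a step that the two limits leave unreadable from compound 1 to compound 2 and it offers no size to carry over, while the limit of > 36600 nM in this assay, at which 2 of the 2 values shown sit, is all the series shows. The expected step of an at least 1.2-fold lower number from compound 2 to compound 3 (0.08 log units; that floor lies within the scatter) is a modest one towards lower numbers in this assay or none that can be read. For compound 3 the estimate is 30000 nM with an expected range of 8000 nM to 60000 nM as its ends.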

Compound 3, half-maximal effective concentration: > 36600 nM
Compound 3: a limit, no number (the forecaster's own chance of this, stated with the estimate: 55%); middle value at least 1.2-fold (0.08 log units) from the limit.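

In this assay, for the compounds shown here, compound 3 gives > 36600 nM, a limit and not a number, so no step from compound 2 can be read. From the compounds shown here alone, whether compound 1, compound 2 and compound 3 differ at all in this assay stays open.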